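The source may report more compounds than this note shows. Statements on the series, on what has been measured and on what is new or still open speak of the compounds shown alone.

Measured compounds:
Compound 1, `CCN(CC)S(=O)(=O)c1ccc(S(=O)(=O)N2CCC[C@@H](C(=O)NC3COC3)C2)cc1`: in an ADME assay on microsomes from liver (Homo sapiens) for metabolic stability, read by LC-MS, using NADPH, with a stated time of 60 min, tested at 10 uM (a lower number here means that the compound disappears faster, a higher number that the compound lasts longer), compound 1 gives 0.308 h.
Compound 2, `CC(C)S(=O)(=O)c1ccc(S(=O)(=O)N2CCC[C@@H](C(=O)N3CCC(F)(F)CC3)C2)cc1`: in this assay compound 2 gives > 1 h, which is a limit of the assay rather than a number.

Compound 2 therefore stands at the upper end of what the two values show, (the limit of > 1 h in this assay, at which 1 of the 2 values shown sits). Compound 3, `CC(C)NS(=O)(=O)c1ccc(S(=O)(=O)N2CCC[C@@H](C(=O)N3CCC(F)(F)CC3)C2)cc1`, differs from compound 2 in one place: isopropylamino in place of isopropyl on a sulfonyl sulfur. Among the compounds with values here, no measured pair shows this exact change, so there is no step to lean on. Compound 3 is expected to stay close to compound 2, with an estimate of 1 h and a range from 0.45 h to 2.2 h. The expected step, a number no higher from compound 2 to compound 3 (the limit leaves the size open), is therefore small, likely no more than the usual scatter.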

Compound 3, half-life: 0.328 h
Estimate against measurement, compound 3: 3.0-fold (0.48 log units) above; the measured number lies below the stated range.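

The sulfonyl sulfur is sensitive to this change: in this assay, putting isopropylamino in place of isopropyl gives an at least 3.0-fold lower number from compound 2 to compound 3 (0.48 log units; beyond the scatter). The earlier compounds shown here could not show this, as they differ in more than one place. Compound 2 carries a limit rather than a number, so the full size of the step is unknown: the limit of > 1 h in this assay, at which 1 of the 3 values shown sits.

The compounds shown do not separate the effect of the added nitrogen from that of its hydrogen. On these data alone, how a dimethylamino group, which has no such hydrogen, would behave on this sulfonyl sulfur remains open.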